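Compound 3 in the naphthyl-free notes: amide aryl swap

The source may hold more compounds than are shown below. What is called first, only, known or untested is meant among the compounds shown, and "the series" means these compounds.

Hmm, title corrected below.

Amide aryl exchange from compound 2 to compound 3

Measured so far in a functional assay on MDA-MB-231 cells (Homo sapiens) for cytotoxicity, with a stated time of 20 h; on this read-out lower numbers stand for higher toxicity in this test and higher numbers for lower toxicity in this test:
- compound 1 `COc1cccc(NC(=O)COc2ccc3cc(/C=C4/SC(=O)NC4=O)ccc3c2)c1`: 9800 nM
- compound 2 `O=C(COc1ccc2cc(/C=C3/SC(=O)NC3=O)ccc2c1)Nc1ccc([N+](=O)[O-])cc1`: 55800 nM

Within the data shown here, compound 2 holds the higher of the two numbers, and compound 1 is its only neighbour. The next change leads to compound 3 `O=C(COc1ccc2cc(/C=C3/SC(=O)NC3=O)ccc2c1)Nc1c(F)cc(F)cc1Br`: 2-bromo-4,6-difluorophenyl in place of 4-nitrophenyl on an amide-type nitrogen. In words, this is 2-bromo-4,6-difluorophenyl in place of 4-nitrophenyl on an amide-type nitrogen. Among the measured compounds shown here, one measured step bears on it, made on the same nitrogen: a 5.7-fold higher number from compound 1 to compound 2 (0.76 log units; beyond the scatter). For the measured compounds named here, no measured compound carries bromine or fluorine, so that step is only a rough guide to size. A move of similar size towards a lower number is expected in this assay, and the expected step is a 2.8-fold lower number from compound 2 to compound 3 (0.45 log units; beyond the scatter). For compound 3 the estimate is 20000 nM, with an expected range of 6000 nM to 65000 nM.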

Compound 3, half-maximal cytotoxic concentration: 9800 nM
The estimate for compound 3 lay 2.0-fold (0.31 log units) above the measured number; low and high end bracket the measured number.
By their numbers in this assay, from the lowest: compounds 1 and 3 (each within the scatter of the next); then compound 2.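

In this assay, the amide aryl position now moves in both directions: a 5.7-fold lower number from compound 2 to compound 3 (0.76 log units; beyond the scatter), so the number reached with 4-nitrophenyl is recovered by a different aryl group. The second comparison, no change at the digits printed from compound 1 to compound 3 (within the scatter), shows that 2-bromo-4,6-difluorophenyl and 3-methoxyphenyl cannot be told apart on this read-out despite their different substituents, which leaves compound 2 alone at the high end among these three compounds. No measured data on these compounds account for the separation of compound 2 from the other two.

Going by these compounds, it remains open whether the higher number of compound 2 goes with the nitro group itself or with its place on the ring, a question that 3-nitrophenyl or 4-aminophenyl on the same nitrogen would address. Also open, on these data alone, is how unsubstituted phenyl or a saturated group such as cyclohexyl would read at this position.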